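The source may report more compounds than this note shows. Statements on the series, on what has been measured and on what is new or still open speak of the compounds shown alone.

Compound 1 `Nc1nc(N/N=C/c2ccc(-c3ccccn3)cc2)nc2c1ncn2[C@@H]1O[C@H](CO)[C@@H](O)[C@H]1O` gives 7540 nM.
Compound 2 `COc1ccc(/C=N/Nc2nc(N)c3ncn([C@@H]4O[C@H](CO)[C@@H](O)[C@H]4O)c3n2)cn1` gives 2.6 nM.
Compound 3 `Nc1nc(N/N=C/c2ccc(-c3ccccc3)cc2)nc2c1ncn2[C@@H]1O[C@H](CO)[C@@H](O)[C@H]1O` gives 7860 nM.

In an assay on CHO-K1 cells for displacement of a labelled ligand from adenosine receptor A1 (Homo sapiens), read by scintillation counting, with a stated time of 60 min (on this read-out higher numbers stand for weaker inhibition and lower numbers for stronger inhibition), compound 3 stands at the highest of the three numbers, which here means the weakest inhibition seen. Compound 1 sits nearest, and the two values lie within the scatter of each other. Compound 2 shows a far lower number, but it differs from compound 3 in more than one place, so only the two values themselves can be compared. Compound 4 `Nc1nc(N/N=C/c2ccc(N3CCCC3)cc2)nc2c1ncn2[C@@H]1O[C@H](CO)[C@@H](O)[C@H]1O` has not yet been measured. It differs from compound 3 by pyrrolidin-1-yl in place of phenyl on an aromatic carbon. Within the data shown here, the one measured step at this place is a 1.0-fold higher number from compound 1 to compound 3 (0.02 log units; within the scatter), where one aromatic ring replaced another without a change beyond the scatter. Among the measured compounds shown here, that step says little about a non-aromatic ring with one hetero atom entering here, and no measured pair covers such a change. For compound 4 in this assay a step of a 3.9-fold lower number from compound 3 to compound 4 (0.59 log units; beyond the scatter) is expected, with wide uncertainty. Compound 4 is estimated at 2000 nM, within a range from 200 nM to 10000 nM.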

Compound 4, inhibition constant: 5.1 nM
For compound 4 the middle estimate is 390-fold (2.59 log units) above the measured one, outside the stated range (below it).
By their numbers in this assay, from the lowest: compounds 2 and 4 (each within the scatter of the next); then compounds 1 and 3 (each within the scatter of the next).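

In this assay the aromatic carbon para to a large group proved highly sensitive to what it carries: aromatic rings had shown no difference there, yet pyrrolidin-1-yl brings a 1500-fold lower number from compound 3 to compound 4 (3.19 log units; beyond the scatter) and a 1500-fold lower number from compound 1 to compound 4 (3.17 log units; beyond the scatter) as well. With a 2.0-fold higher number from compound 2 to compound 4 (0.29 log units; within the scatter) the 4-(pyrrolidin-1-yl)phenyl and 6-methoxypyridin-3-yl groups give values that cannot be told apart in this read-out, so two quite different groups reach the same range. Nothing measured here accounts for the large steps.

The compounds shown leave open whether the ring nitrogen or the non-aromatic ring goes with the large step, which a cyclopentyl group and an open-chain dimethylamino group at this place could separate. As far as these compounds go, how a piperidin-1-yl or morpholin-4-yl ring would read there also remains unknown.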